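Working notes: compound 2 to compound 3

The source may report more compounds than this note shows. Statements on the series, on what has been measured and on what is new or still open speak of the compounds shown alone.

In a physicochemical assay for lipophilicity (on this read-out higher numbers stand for higher lipophilicity and lower numbers for lower lipophilicity), compound 1 `COc1ccc(C2=NO[C@]3(C2)C(=O)O[C@@H]2[C@H]3CC[C@H](C)[C@]3(O)C=CC(=O)[C@@]23C)cc1` gives 1.47 and compound 2 `C[C@H]1CC[C@@H]2[C@@H](OC(=O)[C@]23CC(c2cccc([N+](=O)[O-])c2)=NO3)[C@]2(C)C(=O)C=C[C@@]12O` gives 1.37, so the two lie within the scatter of each other. In compound 3 `Cc1ccc(C2=NO[C@]3(C2)C(=O)O[C@@H]2[C@H]3CC[C@H](C)[C@]3(O)C=CC(=O)[C@@]23C)cc1`, 4-methylphenyl stands in place of 3-nitrophenyl on a carbon with a double bond to nitrogen: 4-methylphenyl in place of 3-nitrophenyl on a carbon with a double bond to nitrogen. Among the compounds with values here, the one measured step at this place is a number 0.10 log units lower from compound 1 to compound 2 (within the scatter). Within the data shown here, no measured step involves 4-methylphenyl, so the expectation remains loose. The expected step in this assay is upward and larger than that earlier step: a number 0.38 log units higher from compound 2 to compound 3 (beyond the scatter). For compound 3 the estimate is 1.75, with an expected range of 1.4 to 2.1.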

Compound 3, partition coefficient: 1.86
The estimate for compound 3 lay 0.11 log units below the measured number; low and high end bracket the measured number.
By their numbers in this assay, from the lowest: compounds 2 and 1 (each within the scatter of the next); then compound 3.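

On this assay this place, on a carbon with a double bond to nitrogen, now gives a step beyond the scatter: 4-methylphenyl in place of 3-nitrophenyl reads as a number 0.49 log units higher from compound 2 to compound 3 (beyond the scatter) in this series. Methyl in place of methoxy on an aromatic carbon gives a number 0.39 log units higher from compound 1 to compound 3 (beyond the scatter) and is also beyond the scatter, whereas the earlier pair stayed within it. Nothing at hand accounts for either step.

Still open, on these data alone, is how an amine or a carboxylic acid on the aromatic ring would read here. As far as these compounds go, a longer chain in place of methyl is equally open.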